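A few compounds are considered here, and "the series" means these few. Any claim that something is new, unique, unknown or untested is made for them only; others in the source may bear on it.

Within the data shown here, compound 3 `Cc1ccc(NC(=O)NC(=O)c2ccc(OCc3ccccc3)cc2)cc1-c1nc2ccccc2[nH]1` is the weakest of the three compounds measured so far in a functional assay on MGC-803 cells (Homo sapiens) for inhibition, read by MTT assay, with a stated time of 48 h (a higher number here means a weaker inhibitor, a lower number a stronger inhibitor), where compound 3 gives 39400 nM. The two other compounds, compound 1 `Cc1ccc(NC(=S)NC(=O)c2ccc(OCc3ccc(C(F)(F)F)cc3)cc2)cc1-c1nc2ccccc2[nH]1` and compound 2 `O=C(NC(=S)Nc1ccc(Cl)c(-c2nc3ccccc3[nH]2)c1)c1ccc(OCc2ccc(Cl)cc2Cl)cc1`, give lower numbers in this assay: compound 1 gives 6500 nM and compound 2 gives 3030 nM, both separated from compound 3 by gaps beyond the scatter. These two compounds differ from compound 3 in several places at once. Their values show only that variants of the shared core can reach lower numbers, not which part of the structure is responsible.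

Compound 4 `Cc1ccc(NC(=O)NC(=O)c2ccc(OCc3ccc(Cl)c(Cl)c3)cc2)cc1-c1nc2ccccc2[nH]1` differs from compound 3 in a single place: 3,4-dichlorophenyl in place of phenyl on a saturated chain carbon bound to an oxygen on an aromatic ring. Among the measured compounds shown here, no measured pair isolates this change. For the measured compounds named here, the only hint comes from compound 1 and compound 2, which carry substituted benzyl groups at the same place and sit lower than compound 3, but other differences accompany that substitution. A modest improvement is therefore expected, with wide uncertainty, and the step of a 2.6-fold lower number from compound 3 to compound 4 (0.42 log units; beyond the scatter) is the estimated size of it. In this assay compound 4 is expected to give about 15000 nM, within a range from 5000 nM to 45000 nM.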

Compound 4, half-maximal inhibitory concentration: 6080 nM
The estimate for compound 4 lay 2.5-fold (0.39 log units) above the measured number; measured number inside the range.
By their numbers in this assay, from the lowest: compounds 2, 4 and 1 (each within the scatter of the next, the first and the last beyond it); then compound 3.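

Replacing phenyl with 3,4-dichlorophenyl on a saturated chain carbon bound to an oxygen on an aromatic ring gives, in this assay, a 6.5-fold lower number from compound 3 to compound 4 (0.81 log units; beyond the scatter). Among these compounds, compounds 1 and 2 differ from compound 3 in several places at once, so this is the first reading of the change on its own, and it shows that the number at this position responds to substitution on the phenyl ring, with a step beyond the scatter. The compounds shown give the size of this step, but nothing available explains it.

As far as these compounds go, it remains open whether a single chlorine would give a step of similar size, or whether both chlorine atoms are needed to reach it. From the compounds shown here alone, it is also open how a methoxy group or an amine on the same ring would compare, and whether the dichloro change would give a similar step in a compound with a thiocarbonyl in place of the carbonyl, the feature that compound 1 and compound 2 carry.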